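The source may hold more compounds than are shown below. What is called first, only, known or untested is meant among the compounds shown, and "the series" means these compounds.

Compound 1 `CCCCNC(=O)N1CC1C#N`, compound 2 `CC(=O)c1cccc(NC(=O)N2CC2C#N)c1` and compound 3 `CNC(=O)N1CC1C#N` share one core and were tested in a functional assay on OVCAR-3 cells (Homo sapiens) for inhibition; a higher number here means a weaker inhibitor, a lower number a stronger inhibitor. Compound 1 gives 12000 nM, compound 2 gives 10000 nM and compound 3 gives 14000 nM. Compound 3 therefore stands among the three numbers with nothing to set it apart: its value differs from that of compound 1 and from that of compound 2 only within the scatter. Within the data shown here, the single step between compounds that differ in one place, a 1.2-fold higher number from compound 1 to compound 3 (0.07 log units; within the scatter), shows that exchanging a propyl chain for hydrogen on the saturated chain carbon bound to the amide-type nitrogen leaves the read-out essentially where it was. Compound 4 `CC(C)(C)NC(=O)N1CC1C#N` differs from compound 3 by tert-butyl in place of methyl on an amide-type nitrogen. Since the size of the group on that nitrogen mattered little in a 1.2-fold higher number from compound 1 to compound 3 (0.07 log units; within the scatter), no step beyond the scatter is expected for a 1.1-fold lower number from compound 3 to compound 4 (0.03 log units; within the scatter). Compound 4 is accordingly estimated at 13000 nM, with a range from 6000 nM to 28000 nM.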

Compound 4, half-maximal inhibitory concentration: 186000 nM
For compound 4 the middle estimate is 14-fold (1.16 log units) below the measured one; the whole stated range lies below it.
By their numbers in this assay, from the lowest: compounds 2, 1 and 3 (each within the scatter of the next); then compound 4.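

In this assay the amide-type nitrogen proves not to be indifferent to what it carries: tert-butyl in place of methyl gives a 13-fold higher number from compound 3 to compound 4 (1.12 log units; beyond the scatter) and tert-butyl in place of butyl gives a 16-fold higher number from compound 1 to compound 4 (1.19 log units; beyond the scatter). Methyl and butyl had stayed within the scatter of each other, so it is the branched tert-butyl, not the mere presence of a larger chain, that separates compound 4 from the others. Nothing shown explains this weakening. The result rests on a single branched group, so the compounds shown leave open whether an isopropyl group or a cyclohexyl ring on that nitrogen would already bring part of the same step. They also leave open how a second branched chain, such as isobutyl, would read.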